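The source may report more compounds than this note shows. Statements on the series, on what has been measured and on what is new or still open speak of the compounds shown alone.

The measured compounds, each with its number in a functional assay on HCT-116 cells (Homo sapiens) for cytotoxicity, read by MTT assay, with a stated time of 48 h; on this read-out higher numbers stand for weaker inhibition and lower numbers for stronger inhibition:

compound 1, `COc1ccc(-c2nn(-c3ccccc3)cc2C(=O)Nc2ccc(Br)cc2)cc1`, gives 5870 nM
compound 2, `COc1ccc(NC(=O)c2cn(-c3ccccc3)nc2-c2ccc(OC)cc2)cc1`, gives 1520 nM
compound 3, `CCOc1ccc(NC(=O)c2cn(-c3ccccc3)nc2-c2ccc(OC)cc2)cc1`, gives 970 nM

Compound 1 stands at the highest of these three numbers. The steps away from it are a 3.9-fold lower number from compound 1 to compound 2 (0.59 log units; beyond the scatter) and a 6.1-fold lower number from compound 1 to compound 3 (0.78 log units; beyond the scatter), while the difference between compound 2 and compound 3 is a 1.6-fold lower number from compound 2 to compound 3 (0.20 log units; within the scatter). Both steps that move beyond the scatter replace the bromo on the anilide ring, and nothing measured touches the other aryl ring of the shared core.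

Compound 4, `O=C(Nc1ccc(Br)cc1)c1cn(-c2ccccc2)nc1-c1ccc(Cl)cc1`, keeps the bromo of compound 1 and differs from it only in chloro in place of methoxy on an aromatic carbon. Among the measured compounds shown here, none of the measured steps bears on this change, since each of them alters a different ring. There is therefore no basis for expecting a step beyond the scatter in either direction in this assay, and the expectation must be broad. Compound 4 is estimated at 5500 nM, with a range from 1500 nM to 20000 nM, which corresponds to an expected step of a 1.1-fold lower number from compound 1 to compound 4 (0.03 log units; within the scatter).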

Compound 4, half-maximal inhibitory concentration: 4360 nM
Beside the measured number, compound 4's estimate is 1.3-fold (0.10 log units) above it; the range from low to high includes it.
By their numbers in this assay, from the lowest: compounds 3 and 2 (each within the scatter of the next); then compounds 4 and 1 (each within the scatter of the next).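

At the other aryl ring of the shared core, the swap from 4-methoxyphenyl to 4-chlorophenyl gives, in this assay, a 1.3-fold lower number from compound 1 to compound 4 (0.13 log units; within the scatter). With the bromo kept on the anilide ring, this position therefore takes chloro in place of methoxy without a step beyond the scatter, whereas the replacements of the bromo in compound 2 and compound 3 did move the number beyond it. No measurement shown here accounts for this result.

The compounds shown leave open how this position responds to other groups, such as an amine, a carboxylic acid or a longer chain like butoxy, as only methoxy and chloro stand there. They also leave open whether chloro at this position would give a similar result alongside the methoxy or ethoxy anilide rings of compound 2 and compound 3.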